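Dichlorophenyl isomers in the amide series

The compounds below may be only part of what the source reports. "The series", "measured", "known", "first", "only" and "open" are said of these compounds alone.

Within the data shown here, in a functional assay on SiHa cells (Homo sapiens) for inhibition (on this read-out higher numbers stand for weaker inhibition and lower numbers for stronger inhibition), compound 3 `COc1cc(/C=C/C(=O)c2cccc(NC(=O)c3ccc(Cl)cc3Cl)c2)ccc1O` gives 34.4 ug/mL, the highest of the three numbers so far. Compound 1 `COc1cc(/C=C/C(=O)c2cccc(NC(=O)c3cccs3)c2)ccc1O` gives 6.57 ug/mL, and compound 2 `COc1cc(/C=C/C(=O)c2cccc(NC(=O)c3ccco3)c2)ccc1O` gives 0.76 ug/mL. Compound 4 `COc1cc(/C=C/C(=O)c2cccc(NC(=O)c3ccc(Cl)c(Cl)c3)c2)ccc1O` is not yet measured. It differs from compound 3 as follows: 3,4-dichlorophenyl in place of 2,4-dichlorophenyl on a carbonyl carbon.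

All three measured steps concern that same place: an 8.6-fold lower number from compound 1 to compound 2 (0.94 log units; beyond the scatter), a 5.2-fold higher number from compound 1 to compound 3 (0.72 log units; beyond the scatter) and a 45-fold higher number from compound 2 to compound 3 (1.66 log units; beyond the scatter). Each lies beyond the scatter, so this assay clearly responds to the group there. None of them, however, compares two dichlorophenyl groups, so direct precedent is lacking. A smaller step than the largest of these is expected, and a lower number is slightly favoured, since compound 3 at 34.4 ug/mL is the top of the range. The expected change is a 1.7-fold lower number from compound 3 to compound 4 (0.24 log units; within the scatter). For compound 4 the estimated value is 20 ug/mL, with an expected range of 5 ug/mL to 60 ug/mL.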

Compound 4, half-maximal inhibitory concentration: 25.3 ug/mL
Compound 4: middle estimate off by 1.3-fold (0.10 log units), on the low side; low and high end bracket the measured number.
By their numbers in this assay, from the lowest: compound 2; then compound 1; then compounds 4 and 3 (each within the scatter of the next).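

In this assay the two dichlorophenyl isomers are not told apart, with a 1.4-fold lower number from compound 3 to compound 4 (0.13 log units; within the scatter), so this change of chlorine pattern on the carbonyl carbon gives no readable effect. The 3,4-dichlorophenyl group also stays clearly separated from both five-membered ring amides, with a 33-fold higher number from compound 2 to compound 4 (1.52 log units; beyond the scatter) and a 3.9-fold higher number from compound 1 to compound 4 (0.59 log units; beyond the scatter), so the gap first seen with 2,4-dichlorophenyl is not confined to that one isomer. No measurement on hand accounts for these numbers.

Still open, from the compounds shown here alone, is whether the gap to furan-2-yl belongs to the chlorines or to the six-membered ring itself, which an unsubstituted phenyl group on the carbonyl carbon would address. Also open, going by these compounds, is how a pyrrolyl group there would compare with furan-2-yl and thiophen-2-yl.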